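A few compounds are considered here, and "the series" means these few. Any claim that something is new, unique, unknown or untested is made for them only; others in the source may bear on it.

Compound 1 `COCCNc1nc(C)nc2c1nnn2-c1c(C)cc(C)cc1C` and compound 2 `CCC(COC)Nc1nc(C)nc2c1nnn2-c1c(C)cc(C)cc1C` share one core, while compound 3 `CCN(CC)c1nc(C)nc2c1ncn2-c1ccc(C(C)C)cc1Br` and compound 4 `CCCCN(CC)c1nc(C)nc2c1ncn2-c1ccc(C(C)C)cc1Br` share another; the difference between the two cores is not broken down here. In an in vitro assay on 293-EBNA cells for binding affinity to corticotropin-releasing factor receptor 1 (Homo sapiens) (a lower number here means a stronger inhibitor, a higher number a weaker inhibitor), compound 1 gives 1200 nM, compound 2 gives 59.4 nM, and compound 3 gives 12.4 nM. The change ethyl in place of hydrogen on a saturated chain carbon bound to a nitrogen on an aromatic ring and a saturated chain carbon produced a 20-fold lower number from compound 1 to compound 2 (1.31 log units; beyond the scatter). Compound 4 carries the same kind of change, (ethyl in place of hydrogen on a saturated chain carbon, two bonds along the chain from a nitrogen on an aromatic ring), but here the added ethyl sits two bonds along the chain from the ring nitrogen rather than on the carbon bound to it, and compound 3 already sits at 12.4 nM. A smaller step is therefore expected for compound 4 in this assay, a 1.6-fold lower number from compound 3 to compound 4 (0.19 log units; within the scatter). Compound 4 is estimated at 8 nM, with a likely range from 3 nM to 25 nM.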

Compound 4, inhibition constant: 4.3 nM
Compound 4: middle estimate off by 1.9-fold (0.27 log units), on the high side; the range from low to high includes it.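

In this assay the new step is a 2.9-fold lower number from compound 3 to compound 4 (0.46 log units; beyond the scatter) and so points the same way as the earlier step on the other core. The direction carries over in these two pairs, but the size does not: the same change on two cores in this assay, a 20-fold lower number (1.31 log units; beyond the scatter) from compound 1 to compound 2 and a 2.9-fold lower number (0.46 log units; beyond the scatter) from compound 3 to compound 4, 7.0-fold (0.85 log units) apart, beyond the scatter of two such steps. The two pairs also differ in where the ethyl sits on the chain, so they cannot show whether the core or the place of the ethyl sets the size of the step.

Going by these compounds, what stays open is how the number would move with a longer chain than butyl on the nitrogen of compound 4, or with an amine or a carboxylic acid at the end of that chain. On these data alone, whether the ethyl would give a similar step at the other place on each core also stays open.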